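The source may report more compounds than this note shows. Statements on the series, on what has been measured and on what is new or still open speak of the compounds shown alone.

Compound 1 (`O=C1/C(=C/c2cccc(F)c2)CCc2ccccc21`): 11900 nM
Compound 2 (`O=C1/C(=C/c2ccc(F)cc2)CCc2ccccc21`): 41200 nM

Within the data shown here, in a functional assay on MOLT-4 cells (Homo sapiens) for inhibition (a lower number here means a stronger inhibitor, a higher number a weaker inhibitor), compound 1 gives 11900 nM as the lower of the two numbers so far, which makes it the stronger inhibitor of the pair. Compound 2 gives 41200 nM as the higher number, and the gap between them lies beyond the usual scatter.

Compound 3 (`Cc1cccc(/C=C2\CCc3ccccc3C2=O)c1`) has not yet been measured. It keeps the core of compound 1 but carries methyl in place of fluoro on an aromatic carbon, meta to a large group (methyl in place of fluoro on an aromatic carbon). Among the measured compounds shown here, no measured pair shows this swap, so the expectation rests only on how small the change is. A slightly higher number is expected, perhaps no larger than the scatter (estimated step: a 1.3-fold higher number from compound 1 to compound 3 (0.10 log units; within the scatter)). For compound 3 the estimated value is 15000 nM (expected range 6000 nM to 40000 nM).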

Compound 3, half-maximal inhibitory concentration: 35800 nM
Compound 3: the middle estimate sits 2.4-fold (0.38 log units) below what was measured; the range from low to high includes it.
By their numbers in this assay, from the lowest: compound 1; then compounds 3 and 2 (each within the scatter of the next).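

In this assay, swapping fluoro for methyl on this aromatic carbon gives a 3.0-fold higher number from compound 1 to compound 3 (0.48 log units; beyond the scatter), so this position responds even to a very small change. The swap exchanges one heavy atom for one heavy atom, and neither group adds a ring, a charge, or a hydrogen-bond donor or acceptor, yet the step still lies beyond the usual scatter. Nothing available here gives a reason for this loss of strength.

As far as these compounds go, two groups at one position cannot show what the position prefers, so it remains open how a chloro group, a methoxy group or an amine at the same carbon would compare with the fluoro of compound 1. It is also unknown whether the same swap would give a step of similar size elsewhere on this ring.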